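Shortening a Hydroxyalkyl Arm on the Core of Compound 1

The compounds below may be only part of what the source reports. "The series", "measured", "known", "first", "only" and "open" are said of these compounds alone.

Compound 1 `CC(C)(C)c1ccc(C(=O)N2CCC3(CC2)C(=O)N(CC(=O)N2CCC(CCO)CC2)CN3c2ccccc2)cc1` was tested in an assay on HEK293 cells for displacement of a labelled ligand from NPC1-like intracellular cholesterol transporter 1 (Homo sapiens) (on this read-out higher numbers stand for weaker inhibition and lower numbers for stronger inhibition), where compound 1 gives 2600 nM. Two other compounds share the core. Compound 2 `COC(=O)CCCNC(=O)CN1CN(c2ccccc2)C2(CCN(C(=O)c3ccc(C4CCCCC4)cc3)CC2)C1=O` gives 2500 nM in this assay, and compound 3 `CC(C)(C)OC(=O)NCNC(=O)CN1CN(c2ccccc2)C2(CCN(C(=O)c3ccc(C4CCCCC4)cc3)CC2)C1=O` gives 1700 nM. Compound 1 has the highest of the three numbers, but its gaps to compound 2 and to compound 3 both lie within the scatter, so the three compounds are not separated in this assay.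

Compound 4 `CC(C)(C)c1ccc(C(=O)N2CCC3(CC2)C(=O)N(CC(=O)N2CCC(O)CC2)CN3c2ccccc2)cc1` is not yet measured. It differs from compound 1 as follows: hydroxy in place of 2-hydroxyethyl on a saturated ring carbon. Among the compounds with values here, the one measured step, a 1.5-fold lower number from compound 2 to compound 3 (0.17 log units; within the scatter), concerns a different part of the molecule and is itself within the scatter, so no measured step bears directly on the change from compound 1 to compound 4. With all three measured numbers lying close together, the expectation for compound 4 is a step of about no change at the digits printed from compound 1 to compound 4 (within the scatter), that is, no shift beyond the scatter. Compound 4 is therefore estimated at 2600 nM in this assay, with a range from 1000 nM to 7000 nM.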

Compound 4, half-maximal inhibitory concentration: 4700 nM
Beside the measured number, compound 4's estimate is 1.8-fold (0.26 log units) below it, and the stated range covers the measured number.
By their numbers in this assay, from the lowest: compounds 3, 2, 1 and 4 (each within the scatter of the next, the first and the last beyond it).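

Replacing 2-hydroxyethyl with hydroxy on the saturated ring carbon in this assay gives a 1.8-fold higher number from compound 1 to compound 4 (0.26 log units; within the scatter), the only step shown at this position. The arm can therefore be cut back to a hydroxy group on the ring, with the hydrogen-bond donor and acceptor counts unchanged, without a shift beyond the scatter. Nothing available explains the size of this step.

The compounds shown leave open whether this ring carbon accepts a primary amine, a carboxylic acid or a longer chain such as 3-hydroxypropyl, since only hydroxy and 2-hydroxyethyl appear there. They also leave open how this change would read alongside a cyclohexyl group in place of tert-butyl, since compound 2 and compound 3 differ from compound 4 in more than one place.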